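Benzyloxycarbonyl on the piperazine nitrogen of a triazole dithiocarbamate

The compounds below may be only part of what the source reports. "The series", "measured", "known", "first", "only" and "open" are said of these compounds alone.

Compounds measured in a functional assay on PC-3 cells (Homo sapiens) for inhibition, read by MTT assay, with a stated time of 72 h; on this read-out higher numbers stand for weaker inhibition and lower numbers for stronger inhibition:
compound 1, `CC(C)(C)OC(=O)N1CCN(C(=S)SCc2cn(-c3ccccc3F)nn2)CC1`: > 128000 nM
compound 2, `Fc1ccc(Cn2cc(CSC(=S)N3CCNCC3)nn2)cc1`: > 128000 nM

Compound 2, `Fc1ccc(Cn2cc(CSC(=S)N3CCNCC3)nn2)cc1`, is one of the two compounds examined so far. In this assay compound 2 gives > 128000 nM, which is a limit of the assay and not a number. Compound 1, `CC(C)(C)OC(=O)N1CCN(C(=S)SCc2cn(-c3ccccc3F)nn2)CC1`, carries a tert-butoxycarbonyl group on the ring amine and a different aryl on the triazole. In this assay compound 1 gives > 128000 nM, likewise a limit of the assay. Within the data shown here, both values therefore sit at the limit of > 128000 nM in this assay, at which 2 of the 2 values shown sit, and no step between the two can be sized. Compound 3, `O=C(OCc1ccccc1)N1CCN(C(=S)SCc2cn(Cc3ccc(F)cc3)nn2)CC1`, is not yet measured. It differs from compound 2 by benzyloxycarbonyl in place of hydrogen on an amine nitrogen in a ring. Among the measured compounds shown here, no measured step covers this change. Since both measured compounds end at the limit, compound 3 is expected to show no shift beyond the scatter, giving an estimated step that the limit leaves unreadable from compound 2 to compound 3. For compound 3 the estimate in this assay is 200000 nM, with a range from 60000 nM to 600000 nM.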

Compound 3, half-maximal inhibitory concentration: > 128000 nM
Compound 3: no number, only a limit; the forecaster's own chance of this, stated with the estimate: 80%; the middle value lies beyond the limit too.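

In this assay compound 3 gives > 128000 nM as a limit of the assay and not a number. Among these compounds, compound 2 also ends at a limit, so no step between compound 2 and compound 3 can be read: the limit of > 128000 nM in this assay, at which 3 of the 3 values shown sit. The compounds shown leave open whether this assay would return a readable value for any change on the ring amine or the triazole.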